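Amide nitrogen variation: chloro added to the phenyl amide

A few compounds are considered here, and "the series" means these few. Any claim that something is new, unique, unknown or untested is made for them only; others in the source may bear on it.

Measured compounds:
compound 1, `Cc1noc(C)c1-c1cnc(N)c(Oc2ccc(C(=O)NC3CC3)cc2)n1`, in a functional assay on U-87MG ATCC cells for inhibition, with U-87 MG (Homo sapiens) as the target, read by MTT assay, with a stated time of 72 h (on this read-out lower numbers stand for stronger inhibition and higher numbers for weaker inhibition), gives 43300 nM
compound 2, `Cc1noc(C)c1-c1cnc(N)c(Oc2ccc(C(=O)NC3CCCCC3)cc2)n1`, in this assay gives 40400 nM
compound 3, `Cc1noc(C)c1-c1cnc(N)c(Oc2ccc(C(=O)Nc3ccccc3)cc2)n1`, in this assay gives 26600 nM

Among the three numbers, the one for compound 3 is the lowest, but a 1.5-fold lower number from compound 2 to compound 3 (0.18 log units; within the scatter) and a 1.6-fold lower number from compound 1 to compound 3 (0.21 log units; within the scatter) are both within the scatter, so the three compounds stand together rather than apart. Compound 4, `Cc1noc(C)c1-c1cnc(N)c(Oc2ccc(C(=O)Nc3cccc(Cl)c3)cc2)n1`, carries the change chloro in place of hydrogen on an aromatic carbon relative to compound 3. Among the measured compounds shown here, none of the measured steps touches the phenyl of the amide itself; the three steps exchange the whole group on the amide-type nitrogen, and a 1.1-fold lower number from compound 1 to compound 2 (0.03 log units; within the scatter), a 1.6-fold lower number from compound 1 to compound 3 (0.21 log units; within the scatter) and a 1.5-fold lower number from compound 2 to compound 3 (0.18 log units; within the scatter) all stay within the scatter. For the measured compounds named here, the shared core has so far tolerated each exchange at this position without a step beyond the scatter, and no measured compound shows what a substituent on that phenyl does. The step of a 1.2-fold lower number from compound 3 to compound 4 (0.08 log units; within the scatter) is therefore expected to lie within the scatter, in no set direction. Compound 4 is expected to give 22000 nM, with a range from 8000 nM to 55000 nM.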

Compound 4, half-maximal inhibitory concentration: 11500 nM
Compound 4: middle estimate off by 1.9-fold (0.28 log units), on the high side; the measured number falls inside the stated range.
By their numbers in this assay, from the lowest: compound 4; then compounds 3, 2 and 1 (each within the scatter of the next).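

In this assay the series shows its first step beyond the scatter between two compounds that differ in one place: a 2.3-fold lower number from compound 3 to compound 4 (0.36 log units; beyond the scatter) comes from a single chloro on the phenyl of the amide, not from exchanging the whole group on the amide-type nitrogen. The 3-chlorophenyl amide also stands apart from the cyclohexyl and cyclopropyl amides, with a 3.5-fold lower number from compound 2 to compound 4 (0.55 log units; beyond the scatter) and a 3.8-fold lower number from compound 1 to compound 4 (0.58 log units; beyond the scatter) as modest steps, which the unsubstituted phenyl amide did not do. Nothing available bears on why this chloro shifts the number.

Going by these compounds, whether the chloro needs this place on the ring stays open, as does whether a fluoro, a methoxy or a trifluoromethyl there would move the number the same way. On these data alone, a carboxylic acid or an amine on that phenyl is equally open.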